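Adding a methoxy to the urea phenyl of compound 3

This account rests on a few compounds, and the source may have more. Where it says the series, first, only, none or still open, it means among the compounds named here.

Measured compounds:
Compound 1, `Cc1ccccc1NC(=O)Nc1cccc(CNc2ncnc3ccccc23)c1`, gives > 50000 nM in a functional assay on HepG2 cells (Homo sapiens) for antiproliferative activity, read by MTT assay (a higher number here means a weaker inhibitor, a lower number a stronger inhibitor), which is a limit of the assay and not a number.
Compound 2, `O=C(Nc1cccc(Cl)c1)Nc1cccc(CNc2ncnc3ccccc23)c1`, gives > 50000 nM in this assay, again a limit.
Compound 3, `COc1cc2ncnc(NCc3cccc(NC(=O)Nc4ccccc4)c3)c2cc1OC`, gives 19700 nM in this assay.

Going by the values given here, compound 3 is therefore the only compound with a number; the other two sit at the limit of > 50000 nM in this assay, at which 2 of the 3 values shown sit. Among the compounds with values here, the single step between measured compounds, a step that the two limits leave unreadable from compound 1 to compound 2, cannot be sized because both ends are limits.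

Compound 4, `COc1ccccc1NC(=O)Nc1cccc(CNc2ncnc3cc(OC)c(OC)cc23)c1`, differs from compound 3 by methoxy in place of hydrogen on an aromatic carbon. Within the data shown here, no measured step touches this position with a number on both sides. Compound 1 does carry a 2-methylphenyl on the urea, but it also lacks the two methoxy groups on the core of compound 3, so its limit and the number of compound 3 cannot be read as one step. With nothing to lean on, the expected step of a 1.3-fold higher number from compound 3 to compound 4 (0.10 log units; within the scatter) is no change beyond the scatter, with a real chance that this assay reports only a limit. Compound 4 is estimated at 25000 nM, between 8000 nM and 70000 nM.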

Compound 4, half-maximal inhibitory concentration: 27200 nM
Compound 4: the middle estimate sits 1.1-fold (0.04 log units) below what was measured; the range from low to high includes it.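

Going by these compounds alone, the urea phenyl now has a step with a number at both ends, which no earlier pair offered: in this assay the change is a 1.4-fold higher number from compound 3 to compound 4 (0.14 log units; within the scatter). Methoxy in place of hydrogen on this six-membered aromatic ring, ortho to a large group, therefore makes no change beyond the scatter, and compound 4 gives a measured number rather than a limit of the assay. On this single step, the position accepts a methoxy without a readable loss or gain, though one group at one place says nothing general about the ring.

The compounds shown leave open whether a different group at this place, such as a hydroxyl, an amine or a carboxylic acid, would move the number beyond the scatter, and whether methoxy on another carbon of this ring would read the same. The effect of swapping 2-methylphenyl for 3-chlorophenyl on the urea also stays unsized, since the step from compound 1 to compound 2 has a limit at both ends and cannot be read: the limit of > 50000 nM in this assay, at which 2 of the 4 values shown sit.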